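Anilide in Place of Methylpiperazine Amide on a Weak Core

The compounds below may be only part of what the source reports. "The series", "measured", "known", "first", "only" and "open" are said of these compounds alone.

Compound 1 `CCCSc1nc(Cl)c2c(n1)N(Cc1ccccc1)C(C(=O)N1CCN(C(=O)OC(C)(C)C)CC1)N2` gives 32000 nM in a functional assay on MGC-803 cells (Homo sapiens) for antiproliferative activity, read by MTT assay, with a stated time of 72 h; on this read-out higher numbers stand for weaker inhibition and lower numbers for stronger inhibition. Compound 2 `CCCSc1nc(Cl)c2c(n1)N(Cc1ccccc1)C(C(=O)N1CCN(C)CC1)N2` reaches only the limit of > 64000 nM in this assay, a limit and not a number. Compound 3 `CCCSc1nc(Cl)c2c(n1)N(CCNC(=O)OC(C)(C)C)C(C(=O)N1CCN(C)CC1)N2` gives 59300 nM in this assay. Compound 2 therefore stands at the boundary of what the assay reports, as recorded in the limit of > 64000 nM in this assay, at which 1 of the 3 values shown sits. Compound 4 `CCCSc1nc(Cl)c2c(n1)N(Cc1ccccc1)C(C(=O)Nc1ccccc1)N2` differs from compound 2 in that (anilino in place of 4-methylpiperazin-1-yl on a carbonyl carbon). Going by the values given here, no measured step alters the amide partner itself; the nearest, an at least 2.0-fold higher number from compound 1 to compound 2 (0.30 log units; that floor lies within the scatter), changes a substituent on that amide's ring, while an at least 1.0-fold lower number from compound 2 to compound 3 (0.03 log units; that floor lies within the scatter) changes a group elsewhere on the core. One expects the step of an at least 1.4-fold lower number from compound 2 to compound 4 (0.15 log units; that floor lies within the scatter), with compound 4 remaining weak. Compound 4 is accordingly estimated at 45000 nM, within 15000 nM to 130000 nM.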

Compound 4, half-maximal inhibitory concentration: 58400 nM
Estimate against measurement, compound 4: 1.3-fold (0.11 log units) below; the range from low to high includes it.
By their numbers in this assay, from the lowest: compounds 1, 4 and 3 (each within the scatter of the next). At a limit, above all of these: compound 2.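

Unlike the earlier steps, this one alters the amide partner itself, on a carbonyl carbon whose other neighbour is a saturated ring carbon. In this assay, anilino in place of 4-methylpiperazin-1-yl gives an at least 1.0-fold lower number from compound 2 to compound 4 (0.03 log units; that floor lies within the scatter), so this swap shows no change that can be told from scatter. The comparison gives only a floor, since it starts from a limit of the assay: the limit of > 64000 nM in this assay, at which 1 of the 4 values shown sits.

Going by these compounds, whether any other amide partner on this core would give a step beyond the scatter stays open. Benzylamino, or an anilino carrying a carboxylic acid or an amine, would test this.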